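Swapping a cyanoguanidine for a thiourea on a four-carbon chain

The source may report more compounds than this note shows. Statements on the series, on what has been measured and on what is new or still open speak of the compounds shown alone.

Of the compounds shown here, three sharing one core have been tested in a functional assay on the whole organism with Rattus norvegicus as the target, at a dose of 100 mg/kg; on this read-out higher numbers stand for more inhibition at the one dose given (going by the name of the read-out) and lower numbers for less inhibition. Compound 1 `CC/N=C(\S)NCCCCCCn1nc(-c2ccccc2)ccc1=O` gives -5.6%, compound 2 `C/N=C(\S)N(C)CCCCn1nc(-c2ccccc2)ccc1=O` gives 17.5%, and compound 3 `C/N=C(/NC#N)N(C)CCCCn1nc(-c2ccccc2)ccc1=O` gives 27%. Compound 3 has the highest number of the three; its gap to compound 2 lies within the scatter, while its gap to compound 1 is clearly beyond it, as seen in a number 32.6 percentage points higher from compound 1 to compound 3 (beyond the scatter). The step of a number 9.5 percentage points higher from compound 2 to compound 3 (within the scatter) is too small to count as a change.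

Compound 4 `CC(C)C/N=C(\S)NCCCCn1nc(-c2ccccc2)ccc1=O` is not yet measured. It differs from compound 3 at one place: a group of 8 heavy atoms (5 carbon, 2 nitrogen, 1 sulfur; no ring) in place of a group of 8 heavy atoms (4 carbon, 4 nitrogen; no ring), on a saturated chain carbon, four bonds along the chain from an aromatic nitrogen. This largely reverses the change seen in the step from compound 1 to compound 3, since a thiourea returns in place of the cyanoguanidine, and the step of a number 23.1 percentage points higher from compound 1 to compound 2 (beyond the scatter) also points to the thiourea end of the series sitting lower. Within the data shown here, on that basis a drop is expected, roughly undoing the earlier rise, though the chain on the thiourea in compound 4 is not the same as in compound 1 and no measured step covers that detail.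

The estimated step is a number 22 percentage points lower from compound 3 to compound 4 (beyond the scatter). For compound 4 the expected value in this assay is 5%, with a range from -15% to 25%.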

Compound 4, a percentage reported as inhibition, in the whole organism at one dose (the size of the read-out at that dose, not a potency): 35.8%
Beside the measured number, compound 4's estimate is 30.8 percentage points below it, and the stated range ends below it.
By their numbers in this assay, from the lowest: compound 1; then compounds 2, 3 and 4 (each within the scatter of the next, the first and the last beyond it).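

In this assay, returning a thiourea at this place, on a saturated chain carbon, four bonds along the chain from an aromatic nitrogen, does not bring the low end of the series back: the record reads a number 8.8 percentage points higher from compound 3 to compound 4 (within the scatter), so compound 3 and compound 4 cannot be told apart here. The thiourea alone therefore does not fix the number, as compound 1, compound 2 and compound 4 all carry one and still differ, with a number 18.3 percentage points higher from compound 2 to compound 4 (beyond the scatter) and a number 41.4 percentage points higher from compound 1 to compound 4 (beyond the scatter), the last step joining two groups with identical heavy-atom counts, so those counts alone do not settle the outcome. No measurement at hand explains these differences.

The steps from compound 1 and compound 2 each alter more than one feature inside the exchanged group, so the shares of the alkyl group on the thiourea, the methyl on the amine nitrogen and the chain remain unseparated. On these data alone, it also remains open how a urea or a benzyl group on the thiourea would read out at this dose, and whether a cyanoguanidine carrying the alkyl group of compound 4 would match compound 4.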